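Amide aryl variation on the shared core: compound 4

This account rests on a few compounds, and the source may have more. Where it says the series, first, only, none or still open, it means among the compounds named here.

Measured compounds:
compound 1 `COc1ccc(C(=O)Nc2cccc(-c3oc4cc(-c5ccc(F)cc5)ccc4c(=O)c3O)c2)cc1` — 8700 nM
compound 2 `O=C(Nc1cccc(-c2oc3cc(-c4ccc(F)cc4)ccc3c(=O)c2O)c1)c1ccc(Cl)cc1` — 10800 nM
compound 3 `O=C(Nc1cccc(-c2oc3cc(-c4ccc(F)cc4)ccc3c(=O)c2O)c1)c1ccc(F)cc1F` — 20500 nM

All three share the same core and differ only in the aryl group on the amide carbonyl. In a functional assay on A549 cells (Homo sapiens) for antiproliferative activity, read by CCK-8 assay, with a stated time of 72 h (on this read-out lower numbers stand for stronger inhibition and higher numbers for weaker inhibition), compound 1 gives the lowest number of the three; compound 2 sits within the scatter of it, as a 1.2-fold higher number from compound 1 to compound 2 (0.09 log units; within the scatter) shows, while compound 3 lies a modest step beyond it, as a 2.4-fold higher number from compound 1 to compound 3 (0.37 log units; beyond the scatter) shows. The step of a 1.9-fold higher number from compound 2 to compound 3 (0.28 log units; within the scatter) is within the scatter.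

Compound 4 `Cc1ccccc1C(=O)Nc1cccc(-c2oc3cc(-c4ccc(F)cc4)ccc3c(=O)c2O)c1` is not yet measured in this assay. It differs from compound 1 by 2-methylphenyl in place of 4-methoxyphenyl on a carbonyl carbon. Within the data shown here, no measured step changes the aryl group to a 2-methylphenyl, so the nearest guides are the two aryl changes that are known: one within the scatter, one a modest rise in the number. A 2-methylphenyl in place of 4-methoxyphenyl is therefore expected to give at most a modest change, with the number more likely to rise than to fall, a 1.3-fold higher number from compound 1 to compound 4 (0.10 log units; within the scatter).

Compound 4 is expected to give about 11000 nM in this assay, within a range from 5000 nM to 25000 nM.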

Compound 4, half-maximal inhibitory concentration: 17600 nM
Compound 4: the middle estimate sits 1.6-fold (0.20 log units) below what was measured; measured number inside the range.
By their numbers in this assay, from the lowest: compounds 1, 2, 4 and 3 (each within the scatter of the next, the first and the last beyond it).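

In this assay, a 2.0-fold higher number from compound 1 to compound 4 (0.31 log units; beyond the scatter) makes 2-methylphenyl a second replacement of the 4-methoxyphenyl on this carbonyl carbon that lands beyond the scatter, here with a group of carbon only. Compound 4 stays within the scatter of the other two replacements, with a 1.2-fold lower number from compound 3 to compound 4 (0.07 log units; within the scatter) and a 1.6-fold higher number from compound 2 to compound 4 (0.21 log units; within the scatter), so the 4-chlorophenyl, 2,4-difluorophenyl and 2-methylphenyl amides cannot be told apart on this read-out, although their aryl groups differ in their substituents. No measurement at hand accounts for any of these steps.

Going by these compounds, whether 4-methylphenyl or 2-methoxyphenyl on the same carbonyl carbon would fall with compound 1 or with compound 4 remains open. Also open, on these data alone, is how an aminophenyl or a non-aromatic cyclohexyl group would read at this place.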